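Aryl swap on the thiophene-bound carbon: compound 4

The compounds below may be only part of what the source reports. "The series", "measured", "known", "first", "only" and "open" are said of these compounds alone.

In an assay on CHO cells for displacement of a labelled ligand from adenosine receptor A3 (Homo sapiens), read by scintillation counting, tested at 10 uM (a lower number here means less inhibition, a higher number more inhibition at the concentration tested (going by the name of the read-out)), compound 1 `CC(C)(C)Cc1c(-c2ccccn2)sc(N)c1C(=O)c1ccc(Cl)cc1` gives 1%. Compound 2 `CC(C)(C)Cc1c(-c2ccc(Cl)cc2)sc(N)c1C(=O)c1ccc(Cl)cc1` gives 1% in this assay, and compound 3 `CC(C)(C)Cc1c(-c2ccc(Cl)c(Cl)c2)sc(N)c1C(=O)c1ccc(Cl)cc1` gives 1% in this assay. On these numbers compound 3 stands level with compounds 1 and 2; its nearest neighbour is compound 1 and its furthest compound 2, and both gaps lie within the scatter.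

The measured steps all change the aromatic group on the same carbon of the shared core. Replacing pyridin-2-yl with 4-chlorophenyl gave no change at the digits printed from compound 1 to compound 2 (within the scatter); replacing pyridin-2-yl with 3,4-dichlorophenyl gave no change at the digits printed from compound 1 to compound 3 (within the scatter); adding chloro in place of hydrogen gave no change at the digits printed from compound 2 to compound 3 (within the scatter). None of the three moved the read-out beyond the scatter.

Compound 4 `COc1ccc(-c2sc(N)c(C(=O)c3ccc(Cl)cc3)c2CC(C)(C)C)cc1` continues this line: 4-methoxyphenyl in place of 3,4-dichlorophenyl on an aromatic carbon. All three steps bear on it, since each exchanges the aromatic group at this position, and each was flat. Within the data shown here, no measured compound with an oxygen-bearing aryl group exists, so the expectation rests only on those flat steps. The step from compound 3 to compound 4 is therefore expected to be a number 1 percentage points higher from compound 3 to compound 4 (within the scatter), with no movement beyond the scatter. Compound 4 is estimated at 2%, in the range -8% to 12%.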

Compound 4, a percentage reported as inhibition, at one concentration (the size of the read-out at that concentration, not a potency): 2%
The estimate for compound 4 equals the measured number at the digits printed, within the range that was stated.
By their numbers in this assay, from the lowest: compounds 1, 2, 3 and 4 (each within the scatter of the next).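

In this assay, 4-methoxyphenyl in place of 3,4-dichlorophenyl gives a number 1 percentage points higher from compound 3 to compound 4 (within the scatter) while methoxy in place of chloro gives a number 1 percentage points higher from compound 2 to compound 4 (within the scatter) and 4-methoxyphenyl in place of pyridin-2-yl gives a number 1 percentage points higher from compound 1 to compound 4 (within the scatter) so an oxygen-bearing aryl group on this carbon, next to the ring sulfur, joins the chlorinated aryl groups and the pyridin-2-yl group without separating from them. The change also takes the aryl group from 0 hydrogen-bond acceptors to 1 at an unchanged 8 heavy atoms, and this difference in counts is not matched by any step beyond the scatter. No available measurement explains why the read-out stays flat across these aryl groups.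

Going by these compounds, all four compounds carry the same neopentyl group, (4-chlorophenyl)carbonyl group and amino group, so the effect of a longer chain in place of the neopentyl group, or of an amide on the amino group, remains open. Also open is whether a carboxylic acid or an aminomethyl group on the aryl ring would move the read-out in this assay beyond the scatter, as every aryl group shown so far leaves it flat at the single concentration tested.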